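The source may report more compounds than this note shows. Statements on the series, on what has been measured and on what is new or still open speak of the compounds shown alone.

Measured so far:
compound 1 `O=C1C[C@H](O)C[C@@H](/C=C/c2c(Cl)cc(Cl)cc2-c2cc(Cl)cc(Cl)c2)O1`: 37 nM
compound 2 `O=C1C[C@H](O)C[C@@H](/C=C/c2ccccc2-c2ccccc2)O1`: 3000 nM
compound 3 `O=C1C[C@H](O)CC(CCc2c(Cl)cc(Cl)cc2-c2ccccc2)O1`: 100 nM

In an assay for inhibition of 3-hydroxy-3-methylglutaryl-coenzyme A reductase (Rattus norvegicus) (on this read-out higher numbers stand for weaker inhibition and lower numbers for stronger inhibition), compound 1 gives the lowest of the three numbers; compound 3 stands nearest, with a higher number that lies beyond the scatter, and compound 2, which carries no chloro groups, stands furthest with a far higher number. No two of these compounds differ in one place only, so the numbers allow no single change to be isolated.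

Compound 4 `Cc1cc(-c2cc(Cl)cc(Cl)c2/C=C/[C@@H]2C[C@@H](O)CC(=O)O2)ccc1F` is to be measured in this assay. It differs from compound 1 by 4-fluoro-3-methylphenyl in place of 3,5-dichlorophenyl on an aromatic carbon. Compounds 2 and 3 show that compounds with fewer chloro groups give higher numbers, though neither pins this to the pendant ring. A moderate weakening beyond the scatter is expected: a 2.4-fold higher number from compound 1 to compound 4 (0.39 log units; beyond the scatter). Compound 4 is estimated at 90 nM, with a range from 30 nM to 280 nM.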

Compound 4, half-maximal inhibitory concentration: 29 nM
For compound 4 the middle estimate is 3.1-fold (0.49 log units) above the measured one, and the stated range ends above it.
By their numbers in this assay, from the lowest: compounds 4 and 1 (each within the scatter of the next); then compound 3; then compound 2.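

In this assay, 4-fluoro-3-methylphenyl in place of 3,5-dichlorophenyl gives a 1.3-fold lower number from compound 1 to compound 4 (0.11 log units; within the scatter). Going by these compounds alone, this position therefore accepts a pendant ring without chloro groups, with no loss beyond the scatter, which the earlier compounds could not show because none isolated this ring. Nothing shown accounts for this match between the two groups.

Still open, going by these compounds, is whether an amine or a carboxylic acid on this pendant ring would hold the number. Also open, on these data alone, is what removing the two chloro groups on the core alone would do.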